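The source may report more compounds than this note shows. Statements on the series, on what has been measured and on what is new or still open speak of the compounds shown alone.

In an in vivo functional assay on the whole organism for inhibition, with Rattus norvegicus as the target (a lower number here means that less compound is needed, a higher number that more compound is needed for the effect), compound 1 (`CCCCc1nc(C)c(CCC(=O)OCC)c(=O)n1Cc1ccc(-c2ccccc2-c2nnn[nH]2)cc1`) gives 0.066 mg/kg and compound 2 (`CCCCc1nc(C)c(CCC(=O)N2CCCCC2)c(=O)n1Cc1ccc(-c2ccccc2-c2nnn[nH]2)cc1`) gives 0.164 mg/kg, the higher of the two numbers. Compound 3 (`CCCCc1nc(C)c(CC(=S)N2CCCCCC2)c(=O)n1Cc1ccc(-c2ccccc2-c2nnn[nH]2)cc1`) is unmeasured. Its change from compound 2 is a group of 9 heavy atoms (7 carbon, 1 nitrogen, 1 sulfur; one seven-membered non-aromatic ring with 1 hetero atom) in place of a group of 9 heavy atoms (7 carbon, 1 nitrogen, 1 oxygen; one six-membered non-aromatic ring with 1 hetero atom), on a saturated chain carbon bound to an aromatic carbon, on a saturated chain carbon bound to an aromatic carbon. Among the measured compounds shown here, the only measured step, a 2.5-fold higher number from compound 1 to compound 2 (0.40 log units; beyond the scatter), is modest and puts piperidin-1-yl in place of ethoxy on a carbonyl carbon. For the measured compounds named here, no measured step covers a group with 1 sulfur or a seven-membered non-aromatic ring. A similarly modest move to a higher number is expected, with the expected step being a 1.5-fold higher number from compound 2 to compound 3 (0.18 log units; within the scatter). For compound 3 the estimate is 0.25 mg/kg, with an expected range of 0.07 mg/kg to 0.8 mg/kg.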

Compound 3, dose for half-maximal effect: 0.034 mg/kg
Estimate against measurement, compound 3: 7.4-fold (0.87 log units) above; the measured number lies below the stated range.
By their numbers in this assay, from the lowest: compounds 3 and 1 (each within the scatter of the next); then compound 2.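

In this assay, the group on a saturated chain carbon bound to an aromatic carbon need not raise the number when it carries a ring: a 4.8-fold lower number from compound 2 to compound 3 (0.68 log units; beyond the scatter). With a 1.9-fold lower number from compound 1 to compound 3 (0.29 log units; within the scatter), the sulfur-bearing group with a seven-membered non-aromatic ring and the ethoxy-bearing group of compound 1 cannot be told apart. Nothing available bears on the reason for the step from the piperidin-1-yl group.

Sulfur and ring size change together, so their shares in the step remain unresolved. A piperidin-1-yl group with sulfur, or a seven-membered ring with carbonyl oxygen, would separate them, while a carboxylic acid would test a different end group.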